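A few compounds are considered here, and "the series" means these few. Any claim that something is new, unique, unknown or untested is made for them only; others in the source may bear on it.

Compound 1 `COc1ccccc1NC(=O)CC1CCc2cc(OC)c(OC)cc21`: 28.1%
Compound 2 `COc1cc2c(cc1OC)C(CC(=O)Nc1cccnc1)CC2`: 25%

In a functional assay on the whole organism (strain Wistar) for inhibition, with Rattus norvegicus as the target, read by paw edema, with a stated time of 1 h, at a dose of 100 mg/kg (on this read-out higher numbers stand for more inhibition at the one dose given (going by the name of the read-out) and lower numbers for less inhibition), compound 2 sits at the lower end of these two numbers, but the step of a number 3.1 percentage points lower from compound 1 to compound 2 (within the scatter) is within the scatter, so the two compounds are not told apart. Compound 3 `COc1cc2c(cc1OC)C(CC(=O)Nc1ccncc1)CC2` differs from compound 2 by pyridin-4-yl in place of pyridin-3-yl on an amide-type nitrogen. Going by the values given here, the one measured step bearing on this, a number 3.1 percentage points lower from compound 1 to compound 2 (within the scatter), also exchanged the aryl group on the amide nitrogen and stayed within the scatter, so no change beyond the scatter is expected. Compound 3 is therefore estimated at 25%, between 10% and 40%, an expected step of no change at the digits printed from compound 2 to compound 3 (within the scatter).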

Compound 3, a percentage reported as inhibition, in the whole organism at one dose (the size of the read-out at that dose, not a potency): 42.2%
For compound 3 the middle estimate is 17.2 percentage points below the measured one; measured number outside the range, above it.
By their numbers in this assay, from the lowest: compounds 2 and 1 (each within the scatter of the next); then compound 3.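

In this assay swapping pyridin-3-yl for pyridin-4-yl on the amide-type nitrogen keeps the same atoms, joined differently, yet gives a number 17.2 percentage points higher from compound 2 to compound 3 (beyond the scatter) and so shows that this position responds to how the pyridine ring is attached. Pyridin-4-yl also stands clear of 2-methoxyphenyl at this place, with a number 14.1 percentage points higher from compound 1 to compound 3 (beyond the scatter) while pyridin-3-yl could not be told apart from it. Nothing measured here explains this gain. Still open, on these data alone, is how pyridin-2-yl or an unsubstituted phenyl on this nitrogen would compare.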